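A few compounds are considered here, and "the series" means these few. Any claim that something is new, unique, unknown or untested is made for them only; others in the source may bear on it.

Of the compounds shown here, three have been measured in a functional assay on a cell-free system (plasma) for inhibition of thromboxane A2 receptor (Homo sapiens), read by turbidimetry; a lower number here means a stronger inhibitor, a higher number a weaker inhibitor. Compound 1 `O=C(O)CCC/C=C\CC1=CCC[C@@H]1NS(=O)(=O)c1ccccc1[N+](=O)[O-]` gives 680 nM. Compound 2 `O=C(O)COCCCC[C@@H]1[C@@H](CNS(=O)(=O)c2ccc(F)cc2)CC[C@H]1F` gives 650 nM, which is the lowest of the three numbers, though the gap to compound 1 lies within the scatter, so the two cannot be told apart. Compound 3 `O=C(O)CC/C=C\C[C@H]1[C@H](F)CC[C@@H]1NS(=O)(=O)c1ccccc1` gives 2000 nM, a number beyond the scatter above that of compound 2.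

Compound 4 `O=C(O)CCC/C=C\C[C@@H]1[C@@H](CNS(=O)(=O)c2ccc(F)cc2)CC[C@H]1F` has not yet been measured in this assay. It differs from compound 2 in one place: 5-carboxypent-1-en-1-yl in place of 3-(carboxymethoxy)propyl on a saturated chain carbon bound to a saturated ring carbon. Going by the values given here, compounds 1 and 3 already carry an alkenyl acid chain of this kind, and their numbers bracket the value of compound 2, so nothing measured so far points to a change that must go in one direction.

Among the compounds with values here, with no measured pair that isolates this change, the step from compound 2 to compound 4 is expected to be small, at most a mild weakening, and possibly none beyond the scatter, giving a 1.4-fold higher number from compound 2 to compound 4 (0.14 log units; within the scatter). Compound 4 is therefore estimated to fall at about 900 nM in this assay, with a likely range from 300 nM to 2700 nM.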

Compound 4, half-maximal inhibitory concentration: 2000 nM
Beside the measured number, compound 4's estimate is 2.2-fold (0.35 log units) below it, within the range that was stated.
By their numbers in this assay, from the lowest: compounds 2 and 1 (each within the scatter of the next); then compounds 3 and 4 (each within the scatter of the next).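

The step at this position is clear: in this assay, placing 5-carboxypent-1-en-1-yl where 3-(carboxymethoxy)propyl stood, on a saturated chain carbon bound to a saturated ring carbon, gives a 3.1-fold higher number from compound 2 to compound 4 (0.49 log units; beyond the scatter). Both groups have 8 heavy atoms and neither has a ring, so this position responds to how the chain is built and not only to its size; compounds 1 and 3 could not show this, as neither differs from compound 2 in one place alone. Nothing measured here accounts for the change in number.

The swap removes the oxygen from the chain and adds a carbon-carbon double bond in one move, so the two changes cannot be separated, and a saturated all-carbon chain carrying the same carboxylic acid would be the natural group for telling them apart. On these data alone, the effect of a longer chain at this position, or of a tetrazole in place of the carboxylic acid, also remains open.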